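This account rests on a few compounds, and the source may have more. Where it says the series, first, only, none or still open, it means among the compounds named here.

Compound 1, `CCOS(=O)(=O)c1ccc(F)c2ncc(I)cc12`, carries an ethoxy group on its sulfonyl sulfur. In an assay for inhibition of methylcytosine dioxygenase TET2 (Homo sapiens), read by mass spectrometry, with stated times of 30 min and 1 h (a lower number here means a stronger inhibitor, a higher number a weaker inhibitor), compound 1 gives > 200000 nM, which is a limit of the assay rather than a number. Compound 2, `NS(=O)(=O)c1ccc(F)c2ncc(I)cc12`, has an amino group in place of that ethoxy. In this assay compound 2 gives 86600 nM. Among the measured compounds shown here, this is the only measured step so far: an at least 2.3-fold lower number from compound 1 to compound 2 (0.36 log units; beyond the scatter). For the measured compounds named here, compound 2 therefore holds the only actual number in this assay; the one other result is the limit of > 200000 nM in this assay, at which 1 of the 2 values shown sits.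

Compound 3, `O=S(=O)(NCc1ccccc1)c1ccc(F)c2ncc(I)cc12`, differs from compound 2 by benzyl in place of hydrogen on a sulfonamide nitrogen. Going by the values given here, no measured step touches the sulfonamide nitrogen itself. Among the compounds with values here, the step from compound 1 to compound 2 alters the group on the sulfonyl sulfur, one bond away, and it shows only that changes around this sulfonyl group can move the number by a modest amount. The expected step is a 1.7-fold lower number from compound 2 to compound 3 (0.24 log units; within the scatter), a small gain that may well stay within the scatter. Compound 3 is estimated at 50000 nM, with a range from 10000 nM to 200000 nM.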

Compound 3, half-maximal inhibitory concentration: > 200000 nM
Compound 3 gave a limit, no number; the forecaster's own chance of this, stated with the estimate: 25%; at least 4.0-fold (0.60 log units) between middle value and limit.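

Benzyl in place of hydrogen on the sulfonamide nitrogen gives an at least 2.3-fold higher number from compound 2 to compound 3 (0.36 log units; beyond the scatter), which is the first measured change at this nitrogen, and it moves the number in the weakening direction. In this assay compound 3 gives > 200000 nM, which is a limit of the assay and not a number, so the step has a lower bound but no known full size. Where compound 1 showed only that replacing ethoxy on the sulfonyl sulfur with amino could bring a number into range, compound 3 shows that this gain does not survive adding benzyl to that amino group, leaving compound 2 as the only one of the three with an actual number: the limit of > 200000 nM in this assay, at which 2 of the 3 values shown sit.

The compounds shown leave open whether any group on this nitrogen weakens the result or whether the loss is specific to benzyl, and a methyl, a short ethyl chain or a phenyl group placed directly on the nitrogen could begin to separate these cases. They also leave open whether a group carrying a carboxylic acid or an amine at this nitrogen would give a measurable number, and how the shared core contributes, since it is the same in all three compounds.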